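This account rests on a few compounds, and the source may have more. Where it says the series, first, only, none or still open, it means among the compounds named here.

Measured so far in a toxicity assay on microsomes from liver (Homo sapiens) for metabolic stability, read by LC-MS, using NADPH, tested at 1 uM; on this read-out lower numbers stand for slow clearance and higher numbers for fast clearance:
- compound 1 `CCOc1ncc(-c2nc(C(F)(F)F)sc2N2CCN(C(=O)Cn3cnc4cccnc43)[C@H](C)C2)cn1`: 0.075 mL/min/kg
- compound 2 `Cc1ncc(-c2nc(C(F)(F)F)sc2N2CCN(C(=O)Cn3cnc4cccnc43)[C@H](C)C2)cn1`: 0.033 mL/min/kg
- compound 3 `CCCc1ncc(-c2nc(C(F)(F)F)sc2N2CCN(C(=O)Cn3cnc4cccnc43)[C@H](C)C2)cn1`: 0.184 mL/min/kg

Compound 3 has the highest number of these three in this assay, which means the fastest clearance. Its nearest neighbour is compound 1, and the gap is a 2.5-fold higher number from compound 1 to compound 3 (0.39 log units; beyond the scatter). Its furthest neighbour is compound 2, with a 5.6-fold higher number from compound 2 to compound 3 (0.75 log units; beyond the scatter).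

The next molecule, compound 4 `COCCOc1ncc(-c2nc(C(F)(F)F)sc2N2CCN(C(=O)Cn3cnc4cccnc43)[C@H](C)C2)cn1`, has not yet been measured. It differs from compound 3 in one place: 2-methoxyethoxy in place of propyl on an aromatic carbon. In words, this is 2-methoxyethoxy in place of propyl on an aromatic carbon.

Going by the values given here, no measured compound carries this exact chain. The closest match is the ethoxy of compound 1, which gives 0.075 mL/min/kg. The most relevant step is therefore a 2.5-fold higher number from compound 1 to compound 3 (0.39 log units; beyond the scatter), read in reverse. The other change at this place, a 2.3-fold lower number from compound 1 to compound 2 (0.36 log units; beyond the scatter), is also modest, so a large jump is not expected. From the compounds shown here alone, the extra length of the new chain remains untested, which keeps the range wide.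

The expected move is a 2.2-fold lower number from compound 3 to compound 4 (0.34 log units; beyond the scatter), a modest fall. For compound 4 the estimated value is 0.085 mL/min/kg, with an expected range from 0.04 mL/min/kg to 0.18 mL/min/kg.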

Compound 4, clearance: 0.221 mL/min/kg
Compound 4: the middle estimate sits 2.6-fold (0.41 log units) below what was measured; measured number outside the range, above it.
By their numbers in this assay, from the lowest: compound 2; then compound 1; then compounds 3 and 4 (each within the scatter of the next).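

In this assay, putting 2-methoxyethoxy in place of propyl on the aromatic carbon between two ring nitrogen atoms gives a 1.2-fold higher number from compound 3 to compound 4 (0.08 log units; within the scatter), so this read-out does not separate the two chains, even though only 2-methoxyethoxy carries hydrogen-bond acceptors. Adding a methoxy to the end of the ethoxy chain gives a 2.9-fold higher number from compound 1 to compound 4 (0.47 log units; beyond the scatter), which shows that an oxygen bound directly to the ring does not by itself hold the number down, and that a second oxygen further out does not either. Methyl remains the group with the lowest number at this position, and replacing it with the new chain gives a 6.7-fold higher number from compound 2 to compound 4 (0.83 log units; beyond the scatter), the widest step among these four compounds.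

Nothing available gives a reason for these steps. Still open, from the compounds shown here alone, is how this position responds to groups of another kind, such as a dimethylamino group or a small ring like cyclopropyl, and whether a longer ether chain would stay level with compound 4 in this assay or move away from it.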